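From iodo to methoxy: working notes on compound 4

A few compounds are considered here, and "the series" means these few. Any claim that something is new, unique, unknown or untested is made for them only; others in the source may bear on it.

In a functional assay on FM3A cells (Mus musculus) for antiproliferative activity, with a stated time of 48 h (on this read-out lower numbers stand for stronger inhibition and higher numbers for weaker inhibition), compound 1 (`C=C(Br)C(=O)Nc1ccc(/C=C/C(=O)c2ccccc2)cc1`) gives 3900 nM and compound 2 (`C=C(Br)C(=O)Nc1ccc(/C=C/C(=O)c2ccc(Cl)c(Cl)c2)cc1`) gives 3200 nM. Compound 3 (`C=C(Br)C(=O)Nc1ccc(/C=C/C(=O)c2ccc(I)cc2)cc1`) gives 8300 nM, the highest number of the three.

Compound 4 (`C=C(Br)C(=O)Nc1ccc(/C=C/C(=O)c2ccc(OC)cc2)cc1`) carries methoxy in place of iodo on an aromatic carbon, para to a large group: methoxy in place of iodo on an aromatic carbon.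

Among the measured compounds shown here, two measured steps bear on this change: a 2.1-fold higher number from compound 1 to compound 3 (0.33 log units; beyond the scatter), with iodo in place of hydrogen, and a 2.6-fold higher number from compound 2 to compound 3 (0.41 log units; beyond the scatter). Both are modest. For the measured compounds named here, no measured compound carries methoxy, so the size of the step rests on these two alone. A modest step to a lower number is expected: a 2.1-fold lower number from compound 3 to compound 4 (0.32 log units; beyond the scatter). Compound 4 is estimated at 4000 nM, with an expected range of 1800 nM to 9000 nM.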

Compound 4, half-maximal inhibitory concentration: 1200 nM
Beside the measured number, compound 4's estimate is 3.3-fold (0.52 log units) above it; measured number outside the range, below it.
By their numbers in this assay, from the lowest: compound 4; then compounds 2 and 1 (each within the scatter of the next); then compound 3.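

Iodo and methoxy at this position pull the number in opposite directions: exchanging iodo for methoxy gives a 6.9-fold lower number from compound 3 to compound 4 (0.84 log units; beyond the scatter), and methoxy in place of hydrogen gives a 3.3-fold lower number from compound 1 to compound 4 (0.51 log units; beyond the scatter), whereas the earlier compounds showed only a rise with iodo. The 4-methoxyphenyl also outdoes the 3,4-dichlorophenyl, with a 2.7-fold lower number from compound 2 to compound 4 (0.43 log units; beyond the scatter), so compound 4 holds the lowest number of the four in this assay.

Nothing available here accounts for the difference between these groups. From the compounds shown here alone, whether an amine, a hydroxyl or a longer alkoxy chain at this position would extend the fall remains open.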